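This account rests on a few compounds, and the source may have more. Where it says the series, first, only, none or still open, it means among the compounds named here.

Measured compounds:
compound 1 `Cc1cc(C)c(NC(=O)N(Cc2cccc(-n3cccc3)c2)C2CCCCCC2)c(C)c1`, in a functional assay on a cell-free system (plasma) with sterol O-acyltransferase, Soat (Rattus norvegicus) as the target (on this read-out lower numbers stand for an effect already at smaller amounts and higher numbers for an effect only at larger amounts of compound), compound 1 gives 0.17 mg/kg
compound 2 `Cc1cc(C)c(NC(=O)N(Cc2cccc(-c3cc[nH]n3)c2)C2CCCCCC2)c(C)c1`, in this assay compound 2 gives 0.097 mg/kg
compound 3 `Cc1cc(C)c(NC(=O)N(Cc2cccc(-c3ccnn3C)c2)C2CCCCCC2)c(C)c1`, in this assay compound 3 gives only a limit of > 1 mg/kg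

Going by the values given here, compound 3 stands at the weak end of the three: its result is a limit, not a number, and it is the one value sitting at the limit of > 1 mg/kg in this assay, at which 1 of the 3 values shown sits. The step of an at least 5.8-fold higher number from compound 1 to compound 3 (0.76 log units; beyond the scatter) and the step of an at least 10-fold higher number from compound 2 to compound 3 (1.01 log units; beyond the scatter) both run upward and beyond the scatter, whereas the step of a 1.8-fold lower number from compound 1 to compound 2 (0.24 log units; within the scatter) stays within it.

Compound 4 `Cc1cc(C)c(NC(=O)N(Cc2cccc(-c3c[nH]cn3)c2)C2CCCCCC2)c(C)c1` is not yet measured. It differs from compound 3 by 1H-imidazol-4-yl in place of 1-methyl-1H-pyrazol-5-yl on an aromatic carbon. This change removes the 1-methyl-1H-pyrazol-5-yl that marks compound 3 as the weakest and installs a five-membered aromatic ring with a ring hydrogen, as in the 1H-pyrazol-3-yl of compound 2 and the 1H-pyrrol-1-yl of compound 1, which sat close together.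

Since the move away from the methylated ring reverses the direction of the steps from compound 1 and compound 2 to compound 3, compound 4 is expected to return toward the numbers of compound 1 and compound 2, giving in this assay a step of an at least 6.6-fold lower number from compound 3 to compound 4 (0.82 log units; beyond the scatter). The estimate for compound 4 in this assay is 0.15 mg/kg, with a range from 0.05 mg/kg to 0.5 mg/kg.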

Compound 4, dose for half-maximal effect: < 1 mg/kg
Compound 4 gave a limit, no number; the forecaster's own chance of this, stated with the estimate: 12%; the middle value lies beyond the limit too.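

In this assay compound 4 gives < 1 mg/kg, which is a limit and not a number. The exchange of 1-methyl-1H-pyrazol-5-yl for 1H-imidazol-4-yl, on an aromatic carbon meta to a large group, gives a number no higher from compound 3 to compound 4 (the limit leaves the size open), so a second ring without the methyl group, besides the 1H-pyrazol-3-yl of compound 2, is now known not to raise the number at this place relative to compound 3. The comparison rests on two limits, which show a direction and give no cause for it: the limit of < 1 mg/kg in this assay, at which 1 of the 4 values shown sits, and (the limit of > 1 mg/kg in this assay, at which 1 of the 4 values shown sits).

From the compounds shown here alone, the steps from compound 1 and compound 2 to compound 4 cannot be read, so it remains open whether 1H-imidazol-4-yl matches the 1H-pyrazol-3-yl and 1H-pyrrol-1-yl groups or falls short of them. Since compound 2 and compound 3 differ both in the methyl group and in how the ring is attached, the compounds shown cannot separate these two changes, and a 1-methyl-1H-imidazol-4-yl or 1-methyl-1H-pyrazol-3-yl group, or an amine or a carboxylic acid at this place, would extend the picture.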